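Bromo to Methoxy Swap Tested on Two Different Rings

This account rests on a few compounds, and the source may have more. Where it says the series, first, only, none or still open, it means among the compounds named here.

Compound 1 `COc1cc(OC)c(/C=C/S(=O)(=O)Cc2ccc(OC)c(N)c2)c(OC)c1` gives 2.5 nM in a functional assay on K562 cells (Homo sapiens) for cytotoxicity, read by trypan blue exclusion, with a stated time of 96 h; on this read-out lower numbers stand for stronger inhibition and higher numbers for weaker inhibition. Compound 2 `COc1cc(OC)c(/C=C/S(=O)(=O)Cc2ccc(Br)c(N)c2)c(OC)c1` gives 750 nM in this assay, and compound 3 `COC(=O)C(Nc1cc(CS(=O)(=O)/C=C/c2c(OC)cc(OC)cc2OC)ccc1OC)c1ccc(Br)cc1` gives 200 nM. Between compound 2 and compound 1 the change is methoxy in place of bromo on an aromatic carbon, and it brought a 300-fold lower number from compound 2 to compound 1 (2.48 log units; beyond the scatter). Compound 3 carries a larger group on a nitrogen on an aromatic ring, and the step of an 80-fold higher number from compound 1 to compound 3 (1.90 log units; beyond the scatter) shows how much that costs. The difference between compound 2 and compound 3 is not broken down here.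

Compound 4 `COC(=O)C(Nc1cc(CS(=O)(=O)/C=C/c2c(OC)cc(OC)cc2OC)ccc1OC)c1ccc(OC)cc1` has not yet been measured. It differs from compound 3 by methoxy in place of bromo on an aromatic carbon. This is the same kind of change that led from compound 2 to compound 1, but the place differs: in compound 2 the bromo sits ortho to an amino group (1 heavy atom) as well as para to a large group, whereas in compound 3 it sits only para to a large group. Because the earlier step of a 300-fold lower number from compound 2 to compound 1 (2.48 log units; beyond the scatter) was so large, some gain is expected, though the estimated step is only a 2.0-fold lower number from compound 3 to compound 4 (0.30 log units; within the scatter). Compound 4 is therefore expected to give about 100 nM, most likely between 20 nM and 500 nM.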

Compound 4, half-maximal inhibitory concentration: 150 nM
Estimate against measurement, compound 4: 1.5-fold (0.18 log units) below; the measured number falls inside the stated range.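

On the core of compound 3, putting methoxy in place of bromo gave a 1.3-fold lower number from compound 3 to compound 4 (0.12 log units; within the scatter), so in this assay this pair shows no reliable effect of the change. The same change therefore did not carry its large effect from one core to the other: the same change on two cores in this assay, a 300-fold lower number (2.48 log units; beyond the scatter) from compound 2 to compound 1 and a 1.3-fold lower number (0.12 log units; within the scatter) from compound 3 to compound 4, 230-fold (2.35 log units) apart, beyond the scatter of two such steps. Within the data shown here, this shows that the step seen on the core of compound 2 cannot simply be transferred to a related core, but it does not show why the two steps part, since the bromo sits on a different ring in each pair and only two pairs are available, too few to give a rule for any further core.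

As far as these compounds go, it remains open whether other groups in that same place, such as fluoro, a nitrile or a carboxylic acid, would also leave the number within the scatter on this core. Also open, from the compounds shown here alone, is what would follow if the methoxycarbonyl group on the nitrogen substituent gave way to a carboxylic acid or an amide.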